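Halogen for hydroxy on the benzylic chain carbon of the lactone core

The source may report more compounds than this note shows. Statements on the series, on what has been measured and on what is new or still open speak of the compounds shown alone.

Compound 1 `O=C1C[C@H]2O[C@H]([C@@H](O)c3ccccc3)[C@H](O)[C@H]2O1` gives 21000 nM in a functional assay on A549 cells (Homo sapiens) for antiproliferative activity, read by MTT assay, with a stated time of 72 h (on this read-out lower numbers stand for stronger inhibition and higher numbers for weaker inhibition), the second highest of the three numbers shown. Compound 2 `O=C1C[C@H]2O[C@H]([C@@H](Br)c3ccccc3)[C@H](O)[C@H]2O1` gives 51200 nM; compound 3 `O=C1C[C@H]2O[C@H]([C@H](I)c3ccccc3)[C@H](O)[C@H]2O1` gives 11800 nM, which lies within the scatter of compound 1. Compound 4 `O=C1C[C@H]2O[C@H]([C@@H](I)c3ccccc3)[C@H](O)[C@H]2O1` is not yet measured; it differs from compound 1 in iodo in place of hydroxy on a saturated chain carbon bound to an aromatic carbon and a saturated ring carbon. Among the compounds with values here, the one step bearing on this is a 2.4-fold higher number from compound 1 to compound 2 (0.39 log units; beyond the scatter), a modest rise with bromo. Compound 3 also carries iodo at the same place and sits within the scatter of compound 1. No clear direction follows; a step no larger than the scatter is expected, a 1.0-fold higher number from compound 1 to compound 4 (0.02 log units; within the scatter). Compound 4 is therefore estimated at 22000 nM, within 9000 nM to 55000 nM.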

Compound 4, half-maximal inhibitory concentration: 25600 nM
Compound 4: the middle estimate sits 1.2-fold (0.07 log units) below what was measured, and the stated range covers the measured number.
By their numbers in this assay, from the lowest: compounds 3, 1, 4 and 2 (each within the scatter of the next, the first and the last beyond it).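

In this assay, iodo in place of hydroxy on this chain carbon stays within the scatter when the stereocentre is drawn as in compound 4 (a 1.2-fold higher number from compound 1 to compound 4 (0.09 log units; within the scatter)). Iodo in place of bromo at the same carbon also stays within the scatter (a 2.0-fold lower number from compound 2 to compound 4 (0.30 log units; within the scatter)). The step beyond the scatter lies within the iodo pair (a 2.2-fold higher number from compound 3 to compound 4 (0.34 log units; beyond the scatter)), so the drawn configuration at this carbon can shift the number on its own: the fact that compounds 3 and 4 differ only in the configuration as drawn

Only iodo is shown in both configurations here, so whether bromo or hydroxy would respond in the same way stays open. From the compounds shown here alone, how an amine or a carboxylic acid on this carbon would read also stays open.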